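The source may report more compounds than this note shows. Statements on the series, on what has been measured and on what is new or still open speak of the compounds shown alone.

Measured compounds:
- compound 1, `CCNC(=O)NS(=O)(=O)c1ccc(-n2nc(C)cc2C)cc1`: in a functional assay on the whole organism (blood, strain albino) with Mus musculus as the target, with stated times of 6 days and 4 h, at a dose of 0.4 mmol/kg by the oral route (a lower number here means less inhibition, a higher number more inhibition at the dose given (going by the name of the read-out)), compound 1 sits at a limit of the assay, < 1%
- compound 2, `Cc1cc(C)n(-c2ccc(S(=O)(=O)NC(=O)NNC(=N)N)cc2)n1`: compound 2 gives 3%
- compound 3, `C=CCNC(=S)NS(=O)(=O)c1ccc(-n2nc(C)cc2C)cc1`: compound 3 gives -1%

Among these, compound 3 holds the lowest of the two numbers; its nearest neighbour is compound 2, the step being a number 4 percentage points lower from compound 2 to compound 3 (within the scatter). The value of compound 1 is a limit only, (the limit of < 1% in this assay, at which 1 of the 3 values shown sits), so the step that the limit leaves unreadable from compound 1 to compound 3 cannot be read.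

The account now moves to compound 4, `CCCNC(=O)NS(=O)(=O)c1ccc(-n2nc(C)cc2C)cc1`. Its change from compound 3 is a group of 6 heavy atoms (4 carbon, 1 nitrogen, 1 oxygen; no ring) in place of a group of 6 heavy atoms (4 carbon, 1 nitrogen, 1 sulfur; no ring), on a sulfonamide nitrogen. Of the measured steps, the one on the same sulfonamide nitrogen, a number 4 percentage points lower from compound 2 to compound 3 (within the scatter), stayed within the scatter, and the step of a number at least 2 percentage points higher from compound 1 to compound 2 (that floor lies within the scatter) on an amide-type nitrogen gave a floor that also lies within the scatter. Within the data shown here, no measured step here has moved the read-out beyond the scatter, so no step beyond the scatter is expected in this assay for compound 4.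

The estimate for compound 4 is therefore 0%, between -8% and 8%. The expected step, a number 1 percentage points higher from compound 3 to compound 4 (within the scatter), is within the scatter, with a fair chance that only a limit is reported.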

Compound 4, a percentage reported as inhibition, in the whole organism at one dose (the size of the read-out at that dose, not a potency): < 1%
Compound 4: a limit, no number; the forecaster's own chance of this, stated with the estimate: 40%; the middle value does not contradict the limit.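

In this assay compound 4 gives < 1%, which is a limit and not a number, so a second compound with a carbamoyl group on the sulfonamide nitrogen now stands at this limit: the limit of < 1% in this assay, at which 2 of the 4 values shown sit. The steps that end or begin at a limit on both the sulfur-for-oxygen exchange and the added methyl on the chain cannot be read, so neither the move to propylcarbamoyl from the sulfur-bearing group nor the lengthening of the chain has a size in this assay. The one step that can be read is a number at least 2 percentage points lower from compound 2 to compound 4 (that floor lies within the scatter), and so no step at this place has yet been shown to lie beyond the scatter.

The compounds shown leave open whether any group on this sulfonamide nitrogen can lift the read-out clear of the limit, and whether real differences lie hidden at it. A longer chain in place of propyl, or a chain ending in an amine or a carboxylic acid, would test this, since the short chains and the group of compound 2 give no readable difference here.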